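Tert-butyl to 4-methylphenyl on the amide: notes on compound 4

This account rests on a few compounds, and the source may have more. Where it says the series, first, only, none or still open, it means among the compounds named here.

Measured in an ADME assay on THP-1 cells (Homo sapiens) for cytotoxicity; on this read-out higher numbers stand for lower toxicity in this test and lower numbers for higher toxicity in this test:
- compound 1 `N#Cc1ccc(NC(=O)c2c(NC(=O)C(F)(F)F)sc3c2CCCCC3)cc1`: 9110 nM
- compound 2 `O=C(Nc1ccc(OC(F)(F)F)cc1)c1c(NC(=O)C(F)(F)F)sc2c1CCCCC2`: 11900 nM
- compound 3 `CC(C)(C)NC(=O)c1c(NC(=O)C(F)(F)F)sc2c1CCCCC2`: > 50000 nM

Compound 3 gives > 50000 nM, which is a limit of the assay and not a number. Compound 4 `Cc1ccc(NC(=O)c2c(NC(=O)C(F)(F)F)sc3c2CCCCC3)cc1` has not yet been measured in this assay. Its structural change is 4-methylphenyl in place of tert-butyl on an amide-type nitrogen.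

Among the compounds with values here, two measured steps bear on this. The closest is an at least 5.4-fold higher number from compound 1 to compound 3 (0.73 log units; beyond the scatter), with tert-butyl in place of 4-cyanophenyl at that same nitrogen, which is the reverse kind of exchange. The other is a 1.3-fold higher number from compound 1 to compound 2 (0.12 log units; within the scatter), with trifluoromethoxy in place of cyano on an aromatic carbon, so the two ring-bearing compounds do not separate. Only these two such compounds are available, so this comparison is thin. Compound 4 is therefore expected to fall back towards them, a step to a lower number of at least modest size, beyond the scatter. Going by these compounds, its exact size stays open, since it starts from a limit. The expected change is an at least 4.5-fold lower number from compound 3 to compound 4 (0.65 log units; beyond the scatter). Compound 4 is estimated at 11000 nM, with an expected range of 5000 nM to 25000 nM.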

Compound 4, half-maximal cytotoxic concentration: > 50000 nM
Compound 4: only a limit was reported; the forecaster's own chance of this, stated with the estimate: 4%; at least 4.5-fold (0.65 log units) between middle value and limit.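

In this assay, an aromatic ring on the amide-type nitrogen does not by itself bring the number down: compound 4, with its 4-methylphenyl group, gives > 50000 nM, which is a limit of the assay and not a number. The ring-bearing compounds, which did not separate before, now do, with an at least 4.2-fold higher number from compound 2 to compound 4 (0.62 log units; beyond the scatter) for methyl in place of trifluoromethoxy and an at least 5.4-fold higher number from compound 1 to compound 4 (0.73 log units; beyond the scatter) for methyl in place of cyano, so the group on the aromatic carbon counts here and not only the choice between tert-butyl and a substituted phenyl on the nitrogen. The step between compound 3 and compound 4 cannot be read, as both stop at the same limit: the limit of > 50000 nM in this assay, at which 2 of the 4 values shown sit.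

Going by these compounds, how far compound 3 and compound 4 lie beyond that limit remains unknown, so no order can be given for tert-butyl and 4-methylphenyl on this nitrogen. The compounds shown also leave open whether an amine or a carboxylic acid in place of methyl on the aromatic carbon would keep compound 4 at the limit or bring the number down.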